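This account rests on a few compounds, and the source may have more. Where it says the series, first, only, none or still open, it means among the compounds named here.

In a functional assay on HT-29 cells (Homo sapiens) for inhibition, read by sulforhodamine B assay, with a stated time of 72 h (on this read-out higher numbers stand for weaker inhibition and lower numbers for stronger inhibition), two compounds with the same core have been measured so far, and they differ only in the group on an amine nitrogen. Compound 1 `CCC(C)NC(=C\C(=O)/C=C/c1ccc(O)c(OC)c1)/C=C/c1ccc(O)c(OC)c1`, with sec-butyl there, gives 22300 nM, and compound 2 `C=CCNC(=C\C(=O)/C=C/c1ccc(O)c(OC)c1)/C=C/c1ccc(O)c(OC)c1`, with allyl there, gives 24600 nM. Among the measured compounds shown here, compound 2 therefore stands level with the only other compound measured, and the two cannot be told apart.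

Compound 3 `COc1cc(/C=C/C(=O)/C=C(/C=C/c2ccc(O)c(OC)c2)NC2CCCCC2)ccc1O` changes the same place, with cyclohexyl in place of allyl on an amine nitrogen. For the measured compounds named here, only one measured step bears on this swap, a 1.1-fold higher number from compound 1 to compound 2 (0.04 log units; within the scatter), which also exchanged one group on that nitrogen for another. That single step stayed within the scatter, but neither group in it holds a ring, so the data do not directly cover cyclohexyl. The range must stay wide for that reason.

The estimated step is a 1.2-fold lower number from compound 2 to compound 3 (0.09 log units; within the scatter), so no change beyond the scatter is expected, and no direction can be favoured. For compound 3, the expected value in this assay is 20000 nM, with an estimated range of 9000 nM to 45000 nM.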

Compound 3, half-maximal inhibitory concentration: > 25000 nM
Compound 3 ended at the assay's limit (the forecaster's own chance of this, stated with the estimate: 5%); middle value at least 1.2-fold (0.09 log units) from the limit.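

In this assay compound 3 gives > 25000 nM, which is a limit of the assay and not a number. Read as floors, the two new steps are an at least 1.0-fold higher number from compound 2 to compound 3 (0.00 log units; that floor lies within the scatter) and an at least 1.1-fold higher number from compound 1 to compound 3 (0.04 log units; that floor lies within the scatter), so neither shows a real gap, and the true distance could be small or large. What compound 3 adds is that a six-membered carbon ring on the amine nitrogen, the first ring seen at this position, brings no stronger inhibition than the open-chain allyl and sec-butyl groups, while whether it weakens inhibition at all stays unreadable because the read-out stops at this point: the limit of > 25000 nM in this assay, at which 1 of the 3 values shown sits.

The compounds shown leave open whether any group on this nitrogen can move the number clearly in either direction, for example a benzyl group, a longer chain, or a chain ending in a carboxylic acid or an amine. All three also share an unchanged core, so they cannot tell whether a change elsewhere in the molecule would do more than a change at this nitrogen.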